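This account rests on a few compounds, and the source may have more. Where it says the series, first, only, none or still open, it means among the compounds named here.

Series notes. Compound 1 `O[C@@H]1[C@H](O)CS[C@H]1Cn1cnc2c(NCc3cccc(I)c3)nc(Cl)nc21` carries chloro on the shared core together with a (3-iodobenzyl)amino group; in an assay on CHO cells for displacement of a labelled ligand from adenosine receptor A1 (Homo sapiens), with a stated time of 60 min, tested at 10 uM (on this read-out higher numbers stand for more inhibition at the one concentration tested (going by the name of the read-out) and lower numbers for less inhibition), compound 1 gives 16.4%. Compound 2 `O[C@@H]1[C@H](O)CS[C@H]1Cn1cnc2c(NCc3cccc(I)c3)ncnc21` differs from compound 1 by hydrogen in place of chloro on an aromatic carbon; in this assay compound 2 gives 9.6%. Compound 3 `O[C@@H]1[C@H](O)CS[C@H]1Cn1cnc2c(NCc3cccc(F)c3)nc(Cl)nc21` differs from compound 1 in the core by fluoro in place of iodo on an aromatic carbon; in this assay compound 3 gives 7.9%, a step of a number 8.5 percentage points lower from compound 1 to compound 3 (within the scatter). Compound 4 `O[C@@H]1[C@H](O)CS[C@H]1Cn1cnc2c(NCc3cccc(F)c3)ncnc21` is not yet measured; it differs from compound 3 by hydrogen in place of chloro on an aromatic carbon. Among the compounds with values here, this is the same kind of change as the one from compound 1 to compound 2, the surroundings differing only in that the place is meta to a (3-fluorobenzyl)amino group rather than meta to a (3-iodobenzyl)amino group. For compound 4 the expected step is a number 4.9 percentage points lower from compound 3 to compound 4 (within the scatter), resting on compound 3 at 7.9% and on the earlier change, which gave a number 6.8 percentage points lower from compound 1 to compound 2 (within the scatter). Compound 4 is therefore estimated at 3%, expected to fall between -8% and 14%.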

Compound 4, a percentage reported as inhibition, at one concentration (the size of the read-out at that concentration, not a potency): 0.3%
Estimate against measurement, compound 4: 2.7 percentage points above; the measured number falls inside the stated range.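

In this assay, hydrogen in place of chloro gives a number 7.6 percentage points lower from compound 3 to compound 4 (within the scatter), and this agrees with the same change made in the presence of the (3-iodobenzyl)amino group: the same change on two cores in this assay, a number 6.8 percentage points lower (within the scatter) from compound 1 to compound 2 and a number 7.6 percentage points lower (within the scatter) from compound 3 to compound 4, 0.8 percentage points apart, within the scatter of two such steps. Fluoro in place of iodo gives a number 9.3 percentage points lower from compound 2 to compound 4 (within the scatter), and this also agrees with its earlier counterpart: the same change on two cores in this assay, a number 8.5 percentage points lower (within the scatter) from compound 1 to compound 3 and a number 9.3 percentage points lower (within the scatter) from compound 2 to compound 4, 0.8 percentage points apart, within the scatter of two such steps. Within this small set, both changes carry from one core to the other without a detectable difference, but since every step lies within the scatter, this does not show that either change has a real effect of its own, and two instances of each change, read at one concentration, establish no general rule or potency difference.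

Going by these compounds, it remains open whether an amine or a longer alkyl chain in place of chloro, on the carbon between two ring nitrogen atoms, would give a step beyond the scatter. The same question stands for a methoxy group or a bromo group in place of the halogen on the benzyl ring.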